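A few compounds are considered here, and "the series" means these few. Any claim that something is new, unique, unknown or untested is made for them only; others in the source may bear on it.

Compound 1 `O=[N+]([O-])c1cn2c(n1)OCC(COc1ccc(-c3ccc(C(F)(F)F)cc3)cn1)C2` gives in this cytotoxicity test a limit of the assay, > 128000 nM.
Compound 2 `O=[N+]([O-])c1cn2c(n1)OCC(COc1ccc(-c3ccc(F)cc3)cn1)C2` likewise gives only a limit of the assay, > 128000 nM.
Compound 3 `O=[N+]([O-])c1cn2c(n1)OCC(COCc1ccc(-c3ccc(C(F)(F)F)cc3)cc1)C2` gives 38000 nM.

The readout is an ADME assay on Vero cells (Chlorocebus sabaeus) for cytotoxicity, with a stated time of 72 h; a higher number here means a weaker inhibitor, a lower number a stronger inhibitor. Compound 2 differs from compound 1 by one change, (fluoro in place of trifluoromethyl on an aromatic carbon), and the step that the two limits leave unreadable from compound 1 to compound 2 cannot be sized, because both values sit at the limit of > 128000 nM in this assay, at which 2 of the 3 values shown sit. Compound 3 shares the nitro-bearing bicyclic core with compound 1, but the difference between the two cores is not broken down here. Compound 3 is the only one of the three with a measured number.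

Compound 4 `O=[N+]([O-])c1cn2c(n1)OCC(COCc1ccc(-c3ccc(F)cc3)cc1)C2` is not yet measured. It differs from compound 3 by fluoro in place of trifluoromethyl on an aromatic carbon, the same change that turns compound 1 into compound 2, placed on the same kind of ring position. Since the measured step that the two limits leave unreadable from compound 1 to compound 2 gives no readable size, the expectation for compound 4 rests mainly on compound 3 and its value 38000 nM. For compound 4 a step of a 1.6-fold higher number from compound 3 to compound 4 (0.20 log units; within the scatter) is expected, with wide uncertainty. Compound 4 is therefore estimated at 60000 nM, within 20000 nM to 128000 nM.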

Compound 4, half-maximal inhibitory concentration: 24000 nM
The estimate for compound 4 lay 2.5-fold (0.40 log units) above the measured number; low and high end bracket the measured number.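

On the core of compound 3, putting fluoro in place of trifluoromethyl gives, in this assay, a 1.6-fold lower number from compound 3 to compound 4 (0.20 log units; within the scatter), so on this core the change cannot be told apart from the ordinary spread of repeated measurements. The same change on the core of compound 1 cannot be read, as compound 1 and compound 2 each give only a limit of the assay and not a number: the limit of > 128000 nM in this assay, at which 2 of the 4 values shown sit. With one readable step and one unreadable step, there is nothing to set side by side, so the data show neither that the change carries over between the two cores nor that it fails to.

The compounds shown leave open whether any group in this place on the ring would give a step beyond the scatter, for instance an amine or a carboxylic acid in place of the fluoro. They also leave open how such a group would read on the core of compound 1, where both values shown are limits.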